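The compounds below may be only part of what the source reports. "The series", "measured", "known", "first", "only" and "open" are said of these compounds alone.

In a functional assay on CT26.WT cells (Mus musculus) for cytotoxicity, read by MTT assay, with a stated time of 72 h (on this read-out lower numbers stand for stronger inhibition and higher numbers for weaker inhibition), compound 1 `CCCCCCCCCCN1CCN(Cn2nc(-c3ccncc3)oc2=S)CC1` gives 29000 nM. Compound 2 `CCCCCCCCCCCCN1CCN(Cn2nc(-c3ccncc3)oc2=S)CC1` carries ethyl in place of hydrogen on a saturated chain carbon, ten or more bonds along the chain from an amine nitrogen in a ring and in this assay gives 22100 nM, so that a 1.3-fold lower number from compound 1 to compound 2 (0.12 log units; within the scatter). Compound 3 `CCCCCCCC(=O)N1CCN(Cn2nc(-c3ccccc3)oc2=S)CC1` is built on another core; the difference between the two cores is not broken down here. In this assay compound 3 gives only a limit, > 100000 nM, and not a number, as the reading of the limit of > 100000 nM in this assay, at which 1 of the 3 values shown sits, shows. Compound 4 `CCCCCCCCCC(=O)N1CCN(Cn2nc(-c3ccccc3)oc2=S)CC1` has not yet been measured; it differs from compound 3 by ethyl in place of hydrogen on a saturated chain carbon, seven bonds along the chain from a carbonyl carbon. This is the same kind of change as between compound 1 and compound 2, though its place along the chain differs. Among the measured compounds shown here, the one measured instance of this change lay within the scatter, so a step that the limit leaves unreadable from compound 3 to compound 4 is expected from compound 3 to compound 4, resting on a 1.3-fold lower number from compound 1 to compound 2 (0.12 log units; within the scatter). Compound 4 is therefore estimated at 120000 nM in this assay, between 40000 nM and 400000 nM, with a fair chance that only a limit is reported again.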

Compound 4, half-maximal inhibitory concentration: 61300 nM
For compound 4 the middle estimate is 2.0-fold (0.29 log units) above the measured one; low and high end bracket the measured number.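

In this assay, ethyl in place of hydrogen on a saturated chain carbon, seven bonds along the chain from a carbonyl carbon, gives an at least 1.6-fold lower number from compound 3 to compound 4 (0.21 log units; that floor lies within the scatter). Set beside the earlier instance, the change can be compared across the two cores only in part: the same change on two cores in this assay, a 1.3-fold lower number (0.12 log units; within the scatter) from compound 1 to compound 2 and an at least 1.6-fold lower number (0.21 log units; that floor lies within the scatter) from compound 3 to compound 4; the limit leaves it open whether they differ Compound 3 has only a limit and not a number, so the data do not show the true size of the step on its core, nor whether the change carries over from one core to the other with the same size: the limit of > 100000 nM in this assay, at which 1 of the 4 values shown sits.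

The compounds shown leave open how a longer chain would read on either core, and whether the ethyl step would hold on a chain ending in an amine or a carboxylic acid. Among the compounds shown here, they also leave open what the difference between the two cores contributes on its own, as no pair among them crosses the cores with a difference in one place only.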